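One Methyl Removed, Measured Once, Expected Again

A few compounds are considered here, and "the series" means these few. Any claim that something is new, unique, unknown or untested is made for them only; others in the source may bear on it.

Compound 1 `COc1cc(O)c(C(=O)/C=C/c2ccc(F)cc2)c(OC)c1` gives, as a limit of the assay and not a number, > 20000 nM in a functional assay on MDA-MB-231 cells (Homo sapiens) for cytotoxicity, with a stated time of 48 h; a lower number here means a stronger inhibitor, a higher number a weaker inhibitor.
Compound 2 `COc1cccc(/C=C/C(=O)c2c(OC)cc(OC)cc2OC)c1` gives 8700 nM in this assay.
Compound 3 `COc1cc(OC)c(C(=O)/C=C/c2ccc(F)cc2)c(OC)c1` gives 10700 nM in this assay.

Compound 2 and compound 3 share a core and differ only in the group on the chain: 3-methoxyphenyl in place of 4-fluorophenyl on a double-bonded chain carbon bound to a double-bonded chain carbon. The step of a 1.2-fold higher number from compound 2 to compound 3 (0.09 log units; within the scatter) is small, so these two values show no difference that can be trusted.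

Compound 3 and compound 1 differ by hydrogen in place of methyl on an oxygen on an aromatic ring. Among the compounds with values here, the step of an at least 1.8-fold higher number from compound 3 to compound 1 (0.27 log units; that floor lies within the scatter) is the one measured example of this change; its floor is set by the limit of > 20000 nM in this assay, at which 1 of the 3 values shown sits, so only a lower bound of the step is known.

Compound 4 `COc1cccc(/C=C/C(=O)c2c(O)cc(OC)cc2OC)c1` has not yet been measured. It differs from compound 2 by hydrogen in place of methyl on an oxygen on an aromatic ring. The place of this change is the same, word for word, as in the change from compound 3 to compound 1, so it is the same change made on the other core, and the two cores differ only in the way given above.

From compound 2 to compound 4 a step of about the same size is expected, a 2.3-fold higher number from compound 2 to compound 4 (0.36 log units; beyond the scatter), resting on the step of an at least 1.8-fold higher number from compound 3 to compound 1 (0.27 log units; that floor lies within the scatter) and on the starting value of compound 2, 8700 nM. For compound 4 the estimated value in this assay is therefore 20000 nM, expected to lie between 9000 nM and 60000 nM, with a real chance that only a limit is reported.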

Compound 4, half-maximal inhibitory concentration: 13200 nM
For compound 4 the middle estimate is 1.5-fold (0.18 log units) above the measured one; low and high end bracket the measured number.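

On the core of compound 2, hydrogen in place of methyl on an oxygen on an aromatic ring, which turns a methoxy group into a hydroxy group, gives a 1.5-fold higher number from compound 2 to compound 4 (0.18 log units; within the scatter) in this assay, so on this core the change shows no difference that can be trusted. Set beside the only other example of the same change, on the core that carries the 4-fluorophenyl group, the comparison reads: the same change on two cores in this assay, an at least 1.8-fold higher number (0.27 log units; that floor lies within the scatter) from compound 3 to compound 1 and a 1.5-fold higher number (0.18 log units; within the scatter) from compound 2 to compound 4; the limit leaves it open whether they differ
These two cores therefore do not show that the change carries over with the same size, and they do not show that it fails to carry over, because the step to compound 1 has only a lower bound, set by a value that is a limit and not a number: the limit of > 20000 nM in this assay, at which 1 of the 4 values shown sits.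

The compounds shown leave open how an amine or a longer alkoxy chain in the place of this methoxy group would read in this assay. They also leave open whether the same swap of methoxy to hydroxy would give a step of similar size on a third core, since two examples, one of them only a lower bound, are too few to set a rule for the series.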